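Phenyl in Place of Amino: Growth Inhibition Expected

The source may report more compounds than this note shows. Statements on the series, on what has been measured and on what is new or still open speak of the compounds shown alone.

Of the compounds shown here, three have been measured in a functional assay on M14 cells (Homo sapiens) for inhibition, read by sulforhodamine B assay, with a stated time of 48 h; on this read-out lower numbers stand for stronger inhibition of growth and higher numbers for weaker inhibition of growth. Compound 1 `N#C/C(=C\N1CCN(C(=O)c2ccco2)C1=S)C(N)=O` gives 16500 nM in this assay. Compound 2 `O=CN1CCN(C(=O)c2ccco2)C1=S` gives 10700 nM, and compound 3 `O=CN1CCN(c2cc(Cl)cc(Cl)c2)C1=S` gives 15600 nM. Compound 1 has the highest of the three numbers, yet its gaps to compound 3 and to compound 2 both fall within the usual scatter of repeated measurements, so none of the three can be set apart from the others on this read-out.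

Compound 4 `N#C/C(=C\N1CCN(C(=O)c2ccco2)C1=S)C(=O)c1ccccc1` has not yet been measured. It differs from compound 1 in one place: phenyl in place of amino on a carbonyl carbon. Cut one bond further out, the same difference reads carbamoyl to benzoyl.

Among the compounds with values here, no measured pair isolates this change, and with compound 1 at 16500 nM and its neighbours all within scatter, there is no footing for a large move in either direction. The step of a 1.3-fold lower number from compound 1 to compound 4 (0.10 log units; within the scatter) is therefore expected to stay within the scatter. Compound 4 is accordingly estimated at 13000 nM, with a range from 4500 nM to 40000 nM.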

Compound 4, concentration for 50% growth inhibition: 14900 nM
Compound 4: the middle estimate sits 1.1-fold (0.06 log units) below what was measured; low and high end bracket the measured number.
By their numbers in this assay, from the lowest: compounds 2, 4, 3 and 1 (each within the scatter of the next).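

In this assay, within the data shown here, the exchange of carbamoyl for benzoyl gives a 1.1-fold lower number from compound 1 to compound 4 (0.04 log units; within the scatter), the first step here that isolates a single change. It shows that, on this carbonyl carbon, amino can give way to phenyl, bringing in an aromatic ring and removing a hydrogen-bond donor, with no difference in growth inhibition that can be told from the scatter. Nothing available bears on why the read-out is so insensitive to this exchange.

Going by these compounds, whether any group on this carbonyl carbon can move the number beyond the scatter stays open, for instance a dimethylamino group, a methoxy group or a methyl group. Also open, on these data alone, is whether a phenyl carrying a chlorine or a hydroxyl group would read the same as the plain phenyl of compound 4.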